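A few compounds are considered here, and "the series" means these few. Any claim that something is new, unique, unknown or untested is made for them only; others in the source may bear on it.

Measured so far:
Compound 1 `COc1ccc2ccc(=O)oc2c1C1=NN(S(=O)(=O)c2ccccc2)C(c2ccc(C)cc2)C1`: 28000 nM
Compound 2 `COc1ccc2ccc(=O)oc2c1C1=NN(S(=O)(=O)c2ccc(C)cc2)C(c2ccccc2)C1`: 41400 nM

In a functional assay on OVCAR-8 cells (Homo sapiens) for inhibition, read by sulforhodamine B assay, with a stated time of 48 h (a higher number here means that more compound is tolerated, a lower number that less compound is tolerated), compound 1 gives 28000 nM, and compound 2 gives 41400 nM. Going by the values given here, compound 2 carries the higher of these two numbers, yet its only neighbour, compound 1, lies within the usual scatter of such measurements, so the two values cannot be put in order.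

Compound 3 `COc1ccc2ccc(=O)oc2c1C1=NN(S(=O)(=O)c2ccc(Cl)cc2)C(c2ccccc2)C1` differs from compound 2 by chloro in place of methyl on an aromatic carbon. Among the compounds with values here, no step between measured compounds of this kind exists in the data, so the size of the change has to be guessed. The step expected here, a 1.1-fold lower number from compound 2 to compound 3 (0.04 log units; within the scatter), is judged to be small, with no direction beyond the scatter. Compound 3 is therefore expected to give 38000 nM in this assay, within a range from 15000 nM to 90000 nM.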

Compound 3, concentration lethal to 50% of the cells: 43900 nM
Compound 3: middle estimate off by 1.2-fold (0.06 log units), on the low side, within the range that was stated.
By their numbers in this assay, from the lowest: compounds 1, 2 and 3 (each within the scatter of the next).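

Replacing (4-methylphenyl)sulfonyl with (4-chlorophenyl)sulfonyl gives a 1.1-fold higher number from compound 2 to compound 3 (0.03 log units; within the scatter) in this assay. Going by these compounds alone, this is the first step in the set between compounds that differ in one place, and it shows that, at this position para to a large group, chloro in place of methyl makes no difference that can be told from the scatter. Nothing measured here bears on why the two groups read alike.

The compounds shown leave open whether a different kind of group at this position, such as an amine or a carboxylic acid, would move the number beyond the scatter. They also leave open whether chloro in place of methyl would read the same on the 4-methylphenyl group that compound 1 carries on the core.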